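The compounds below may be only part of what the source reports. "The series", "measured", "known", "first", "only" and "open" are said of these compounds alone.

Measured compounds:
- compound 1, `CCOc1ccc(C(=O)/C=C/c2c(/C=C/c3ccc(OC)cc3)cc(OC)cc2OC)cc1`: 8 ug/mL
- compound 2, `COc1ccc(/C=C/c2cc(OC)cc(OC)c2/C=C/C(=O)c2ccccc2)cc1`: 6.8 ug/mL
- compound 3, `COc1ccc(/C=C/c2cc(OC)cc(OC)c2/C=C/C(=O)c2ccc(Cl)c(Cl)c2)cc1`: 10.8 ug/mL

These three compounds were tested in a functional assay on HepG2 cells (Homo sapiens) for antiproliferative activity, read by MTT assay, with a stated time of 48 h; on this read-out lower numbers stand for stronger inhibition and higher numbers for weaker inhibition. Compound 3 stands at 10.8 ug/mL in this assay; the step of a 1.4-fold higher number from compound 1 to compound 3 (0.13 log units; within the scatter) and the step of a 1.6-fold higher number from compound 2 to compound 3 (0.20 log units; within the scatter) both stay within the scatter, so on these numbers compound 3 cannot be told apart from compound 1 or compound 2. The step of a 1.2-fold lower number from compound 1 to compound 2 (0.07 log units; within the scatter) is also within the scatter.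

Compound 4, `COc1ccc(/C=C/c2cc(OC)cc(OC)c2/C=C/C(=O)c2ccc(C)c(C)c2)cc1`, has not yet been measured. It differs from compound 3 in one place: 3,4-dimethylphenyl in place of 3,4-dichlorophenyl on a carbonyl carbon. Among the compounds with values here, the steps that bear on this change are those that already alter the group on the carbonyl carbon, a 1.4-fold higher number from compound 1 to compound 3 (0.13 log units; within the scatter) and a 1.6-fold higher number from compound 2 to compound 3 (0.20 log units; within the scatter), and both are within the scatter. On that basis no step beyond the scatter is expected from compound 3 to compound 4 in this assay, and the expected step is a 1.2-fold lower number from compound 3 to compound 4 (0.08 log units; within the scatter). Compound 4 is therefore estimated at 9 ug/mL, with a range from 5 ug/mL to 17 ug/mL.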

Compound 4, half-maximal inhibitory concentration: 0.2 ug/mL
Beside the measured number, compound 4's estimate is 45-fold (1.65 log units) above it; the whole stated range lies above it.
By their numbers in this assay, from the lowest: compound 4; then compounds 2, 1 and 3 (each within the scatter of the next).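

In this assay the group on the carbonyl carbon proves able to change the result sharply: with 3,4-dimethylphenyl in place of 3,4-dichlorophenyl there is a 54-fold lower number from compound 3 to compound 4 (1.73 log units; beyond the scatter) in the number, while the earlier changes at this place all stayed within the scatter. The other two comparisons agree, since a 34-fold lower number from compound 2 to compound 4 (1.53 log units; beyond the scatter) and a 40-fold lower number from compound 1 to compound 4 (1.60 log units; beyond the scatter) are also beyond the scatter, so compound 4 stands apart from all three earlier compounds. Nothing shown here explains why this one swap matters so much.

The compounds shown leave open whether both methyl groups are needed, as a phenyl ring carrying only one methyl group is not among them. They also leave open how a methoxy group or an amine on this ring would compare.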